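From dimethylcarbamoyl to bromo on the shared core

A few compounds are considered here, and "the series" means these few. Any claim that something is new, unique, unknown or untested is made for them only; others in the source may bear on it.

Measured in an ADME assay on J774 cells (Mus musculus) for cytotoxicity; on this read-out higher numbers stand for an effect only at larger amounts of compound and lower numbers for an effect already at smaller amounts:
- Compound 1 `CCCCc1cc2c(=O)cc[nH]c2cc1OCCOc1ccccc1` gives > 20000 nM, a limit.
- Compound 2 `CCCCc1cc2c(=O)c(C(=O)NC)c[nH]c2cc1OCCOc1ccccc1` gives > 20000 nM, a limit.
- Compound 3 `CCCCc1cc2c(=O)c(C(=O)N(C)C)c[nH]c2cc1OCCOc1ccccc1` gives 15300 nM, a number.

Of the three, only compound 3 has a number. The others rest at the limit of > 20000 nM in this assay, at which 2 of the 3 values shown sit. Compound 4 `CCCCc1cc2c(=O)c(Br)c[nH]c2cc1OCCOc1ccccc1` carries bromo in place of dimethylcarbamoyl on an aromatic carbon. Among the measured compounds shown here, no measured step involves bromo. Dimethylcarbamoyl in place of hydrogen gave an at least 1.3-fold lower number from compound 1 to compound 3 (0.11 log units; that floor lies within the scatter), and methylcarbamoyl in place of hydrogen gave a step that the two limits leave unreadable from compound 1 to compound 2. Neither establishes a step beyond the scatter, so none beyond it is expected in this assay, in either direction. The step expected is a 1.0-fold higher number from compound 3 to compound 4 (0.02 log units; within the scatter). For compound 4 the estimated value is 16000 nM, with an expected range from 7000 nM to 35000 nM.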

Compound 4, half-maximal effective concentration: 8070 nM
Beside the measured number, compound 4's estimate is 2.0-fold (0.30 log units) above it; the measured number falls inside the stated range.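

In this assay, among the compounds shown here, bromo is the first group on this aromatic carbon to give steps beyond the scatter, with an at least 2.4-fold lower number from compound 1 to compound 4 (0.39 log units; beyond the scatter) and an at least 2.4-fold lower number from compound 2 to compound 4 (0.39 log units; beyond the scatter). Against dimethylcarbamoyl the change does not separate the two groups, with a 1.9-fold lower number from compound 3 to compound 4 (0.28 log units; within the scatter). The first two steps are floors rather than sizes, as compound 1 and compound 2 each stand at a limit: the limit of > 20000 nM in this assay, at which 2 of the 4 values shown sit.

On these data alone, what an amine, a carboxylic acid or chloro would give on this carbon stays open, as does the true size of those two steps.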